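Capping the hydroxy of compound 2 as methoxy

The source may report more compounds than this note shows. Statements on the series, on what has been measured and on what is new or still open speak of the compounds shown alone.

Three compounds were tested in an assay for inhibition of HSP60/HSP10 (Homo sapiens), with a stated time of 60 min; on this read-out higher numbers stand for weaker inhibition and lower numbers for stronger inhibition. Compound 1 `O=C(Nc1ccccc1)c1cc(Br)ccc1O` reaches only the limit of the assay, > 100000 nM. Compound 2 `O=C(Nc1cccc(Cl)c1)c1ccccc1O` likewise gives only a limit, > 100000 nM. Compound 3 `O=C(Nc1cccc(Cl)c1)c1cc(Br)cc(Br)c1` also stops at a limit, > 100000 nM. For the measured compounds named here, compound 2 therefore stands where every value shown stands, at the limit of > 100000 nM in this assay, at which 3 of the 3 values shown sit, and no step between measured compounds can be read from these results. Compound 4 `COc1ccccc1C(=O)Nc1cccc(Cl)c1` differs from compound 2 by methyl in place of hydrogen on an oxygen on an aromatic ring, that is, hydroxy to methoxy. Going by the values given here, no measured step for a change of this kind is available, so nothing beyond the scatter is expected in this assay in either direction. The step from compound 2 to compound 4 is estimated as a step that the limit leaves unreadable from compound 2 to compound 4. Compound 4 is expected to give 150000 nM in this assay, within 50000 nM to 500000 nM, most likely again only as a limit.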

Compound 4, half-maximal inhibitory concentration: > 100000 nM
Compound 4 was reported as a limit (the forecaster's own chance of this, stated with the estimate: 85%); the middle value does not contradict the limit.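

In this assay, for the compounds shown here, compound 4 gives only a limit, as compound 2 does, so no step between these two compounds can be read. The compounds shown leave open whether in this assay any change to the shared core gives a number rather than a limit.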